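The compounds below may be only part of what the source reports. "The series", "measured", "known", "first", "only" and "open" are said of these compounds alone.

Measured compounds:
compound 1 `O=C(O)CCC(=O)OCCCCCCSc1ccc([N+](=O)[O-])c2nonc12` — 3640 nM
compound 2 `Cc1ccc(NC(=O)CCC(=O)OCCCCCCSc2ccc([N+](=O)[O-])c3nonc23)cc1` — 5240 nM

In a functional assay on A549 cells (Homo sapiens) for inhibition, read by MTT assay, with a stated time of 72 h (on this read-out lower numbers stand for stronger inhibition and higher numbers for weaker inhibition), compound 1 gives 3640 nM and holds the lowest of the two numbers; the nearest is compound 2, with 5240 nM, separated by a 1.4-fold higher number from compound 1 to compound 2 (0.16 log units; within the scatter), a step that lies within the scatter, so no order between the two can be claimed.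

Compound 3 `COc1ccc(NC(=O)CCC(=O)OCCCCCCSc2ccc([N+](=O)[O-])c3nonc23)cc1OC` remains to be measured in this assay. Relative to compound 1 the change is (3,4-dimethoxyphenyl)amino in place of hydroxy on a carbonyl carbon. Among the compounds with values here, the one measured step that bears on it, replacing the same hydroxy with an arylamino on the same carbonyl carbon, is a 1.4-fold higher number from compound 1 to compound 2 (0.16 log units; within the scatter), which did not leave the scatter. On that basis no step beyond the scatter is expected in this assay from compound 1 to compound 3. The expected step is a 1.3-fold higher number from compound 1 to compound 3 (0.12 log units; within the scatter). The estimate for compound 3 in this assay is 4800 nM, with a range from 2000 nM to 11000 nM.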

Compound 3, half-maximal inhibitory concentration: 3890 nM
Compound 3: the middle estimate sits 1.2-fold (0.09 log units) above what was measured; the measured number falls inside the stated range.
By their numbers in this assay, from the lowest: compounds 1, 3 and 2 (each within the scatter of the next).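

In this assay, the (3,4-dimethoxyphenyl)amino group on the carbonyl carbon stays within the scatter of the hydroxy compound (a 1.1-fold higher number from compound 1 to compound 3 (0.03 log units; within the scatter)), so a second arylamino group, with its six-membered aromatic ring and two further hydrogen-bond acceptors, reads like the first. Changing the aryl group itself, 3,4-dimethoxyphenyl in place of 4-methylphenyl on the amide-type nitrogen, also stays within the scatter (a 1.3-fold lower number from compound 2 to compound 3 (0.13 log units; within the scatter)), so compounds 1, 2 and 3 show no step beyond the scatter at this position. Nothing available explains why these numbers stay together.

On these data alone, whether a non-aromatic group at this carbonyl carbon, such as a morpholine amide or a simple alkylamino group, would move the number remains open. Also open, as far as these compounds go, is whether a longer chain in the linker would produce a step beyond the scatter.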